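Swapping 4-aminophenyl for 1-phenylethyl on the shared core

The compounds below may be only part of what the source reports. "The series", "measured", "known", "first", "only" and "open" are said of these compounds alone.

Compound 1 `Nc1ccc(Nc2c(C(=O)NCc3ccc(F)cc3)nc(Br)c3cccnc23)cc1`: 7000 nM
Compound 2 `COc1cccc(CNC(=O)c2nc(Br)c3cccnc3c2N[C@H]2CC[C@H](N)CC2)c1`: 7000 nM
Compound 3 `C[C@H](NC(=O)c1nc(Br)c2cccnc2c1N[C@H]1CC[C@H](N)CC1)c1ccc(F)cc1`: > 10000 nM (a limit, not a number)

In a functional assay on MDA-MB-435 cells (Homo sapiens) for cytotoxicity, read by MTT assay, with a stated time of 72 h (a higher number here means a weaker inhibitor, a lower number a stronger inhibitor), compound 1 gives 7000 nM, the same figure as compound 2 at 7000 nM. Compound 3 reads > 10000 nM, which is a limit of the assay. The next compound, compound 4 `C[C@H](Nc1c(C(=O)NCc2ccc(F)cc2)nc(Br)c2cccnc12)c1ccccc1`, keeps the core of compound 1 but carries 1-phenylethyl in place of 4-aminophenyl on a nitrogen on an aromatic ring.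

For the measured compounds named here, only one measured step is available, an at least 1.4-fold higher number from compound 2 to compound 3 (0.15 log units; that floor lies within the scatter). It changes a group on an amide-type nitrogen, not the group swapped here, so it bears on this change only loosely. Going by the values given here, no measured step covers this swap, so no shift beyond the scatter is expected in this assay, and the expectation stays anchored on compound 1 at 7000 nM.

The estimated change is no change at the digits printed from compound 1 to compound 4 (within the scatter). The expected value for compound 4 is 7000 nM, with an estimated range of 2500 nM to 20000 nM.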

Compound 4, half-maximal inhibitory concentration: > 20000 nM
Compound 4 gave a limit, no number (the forecaster's own chance of this, stated with the estimate: 30%); at least 2.8-fold (0.45 log units) between middle value and limit.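

For the compounds shown here, until now, the only measured step concerned a group on an amide-type nitrogen, and its floor lay within the scatter. In this assay, placing 1-phenylethyl in place of 4-aminophenyl on a nitrogen on an aromatic ring gives an at least 2.8-fold higher number from compound 1 to compound 4 (0.45 log units; beyond the scatter), so this is the first change shown that moves the read-out beyond the scatter, and it points to the weaker side. Compound 4 reads a limit rather than a number, so the step gives only a floor: the limit of > 20000 nM in this assay, at which 1 of the 4 values shown sits.

The swap removes the amino group and the directly attached aromatic ring together, and the compounds shown leave open which of these differences counts. From the compounds shown here alone, a plain phenyl or a benzyl group on the same nitrogen would help to separate them, and whether the same swap behaves alike with other amide groups also remains open.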